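This account rests on a few compounds, and the source may have more. Where it says the series, first, only, none or still open, it means among the compounds named here.

Measured compounds:
- Compound 1, `CC(C)n1ncc2c(C(=O)Nc3cncnc3)cc(-c3cccs3)nc21`: in an ADME assay on LLC-MK2 cells (Macaca mulatta) for cytotoxicity, read by spectrophotometry and crystal violet staining, with a stated time of 4 days (a higher number here means that more compound is tolerated, a lower number that less compound is tolerated), compound 1 gives 20000 nM.
- Compound 2, `CC(C)n1ncc2c(C(=O)Nc3ccccc3F)cc(-c3cccs3)nc21`: compound 2 gives 50000 nM.
- Compound 3, `CC(C)n1ncc2c(C(=O)Nc3ccccn3)cc(-c3cccs3)nc21`: compound 3 gives only a limit of the assay, > 200000 nM.

Compound 3 thus stands at the top of the three values, and its value is a limit rather than a number, as shown by the limit of > 200000 nM in this assay, at which 1 of the 3 values shown sits. Of the two steps that lead to it, an at least 10-fold higher number from compound 1 to compound 3 (1.00 log units; beyond the scatter) and an at least 4.0-fold higher number from compound 2 to compound 3 (0.60 log units; beyond the scatter), both point upward and both lie beyond the scatter, so the ring on the amide-type nitrogen clearly matters for how much compound the cells tolerate.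

Compound 4, `CC(C)n1ncc2c(C(=O)Nc3ncccn3)cc(-c3cccs3)nc21`, differs from compound 3 in one place: pyrimidin-2-yl in place of pyridin-2-yl on an amide-type nitrogen. Going by the values given here, no measured step swaps pyridin-2-yl for pyrimidin-2-yl, so the expectation rests on compound 3 already sitting at the limit and on the two steps above. Since compound 3 sits at > 200000 nM, a step that is not beyond the scatter is expected, a number no higher from compound 3 to compound 4 (the limit leaves the size open), with a fair chance that only a limit is reported again.

Compound 4 is therefore estimated to give 200000 nM, within a range from 70000 nM to 600000 nM.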

Compound 4, half-maximal cytotoxic concentration: 75000 nM
Compound 4: the middle estimate sits 2.7-fold (0.43 log units) above what was measured; the measured number falls inside the stated range.
By their numbers in this assay, from the lowest: compound 1; then compounds 2 and 4 (each within the scatter of the next). At a limit, above all of these: compound 3.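

In this assay, pyrimidin-2-yl in place of pyridin-2-yl on the amide-type nitrogen gives an at least 2.6-fold lower number from compound 3 to compound 4 (0.42 log units; beyond the scatter), the first sign that one more ring nitrogen at this place can lower the amount of compound the cells tolerate, though the true size of the step stays open since the value of compound 3 is a limit and not a number: the limit of > 200000 nM in this assay, at which 1 of the 4 values shown sits.

The two pyrimidine groups also give different results, with a 3.8-fold higher number from compound 1 to compound 4 (0.57 log units; beyond the scatter), so groups of the same name that differ only in how they are joined to the amide-type nitrogen do not behave alike here. Pyrimidin-2-yl in place of 2-fluorophenyl gives a 1.5-fold higher number from compound 2 to compound 4 (0.18 log units; within the scatter), so the cell test does not separate these two compounds, even though one group carries ring nitrogens and the other a fluorine.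

The compounds shown leave open how pyridin-3-yl or pyridin-4-yl would behave at this place, and whether a ring is needed there at all, as opposed to a simple chain such as ethyl or a morpholine group. They also give no account of why these rings differ, since they show only how much compound the cells tolerate.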